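A few compounds are considered here, and "the series" means these few. Any claim that something is new, unique, unknown or untested is made for them only; others in the source may bear on it.

Three compounds share one core and differ only in the group on the amide-type nitrogen. Compound 3 `O=C(Nc1ccc(F)cc1)c1cncc(N2CC3CC(C2)N3)c1` carries a 4-fluorophenyl and gives 81 nM in an assay on cells for displacement of a labelled ligand from Neuronal acetylcholine receptor; alpha3/beta4 (Homo sapiens); a lower number here means a stronger inhibitor, a higher number a weaker inhibitor. Compound 1 `O=C(Nc1ccc(I)cc1)c1cncc(N2CC3CC(C2)N3)c1` gives 103 nM, and compound 2 `O=C(Nc1ccc(Cl)cc1)c1cncc(N2CC3CC(C2)N3)c1` gives 123 nM. Compound 3 shows the smallest number of the three, but the steps of a 1.3-fold lower number from compound 1 to compound 3 (0.10 log units; within the scatter) and a 1.5-fold lower number from compound 2 to compound 3 (0.18 log units; within the scatter) both lie within the scatter, so no order among them can be claimed. Compound 4 `COc1cccc(NC(=O)c2cncc(N3CC4CC(C3)N4)c2)c1` is not yet measured; (3-methoxyphenyl in place of 4-fluorophenyl on an amide-type nitrogen). The measured steps only exchanged one halogen for another at the same place, including a 1.2-fold higher number from compound 1 to compound 2 (0.08 log units; within the scatter), and none introduces a methoxy group, so they guide only weakly. Compound 4 is therefore expected near its neighbours, estimated at 110 nM with a range of 40 nM to 300 nM, a step of a 1.4-fold higher number from compound 3 to compound 4 (0.13 log units; within the scatter) expected to stay within the scatter.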

Compound 4, inhibition constant: 265 nM
For compound 4 the middle estimate is 2.4-fold (0.38 log units) below the measured one; low and high end bracket the measured number.
By their numbers in this assay, from the lowest: compounds 3, 1 and 2 (each within the scatter of the next); then compound 4.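

Swapping one halogen for another left the numbers within the scatter, but this position does respond to a different group. In this assay the 3-methoxyphenyl gives a 3.3-fold higher number from compound 3 to compound 4 (0.51 log units; beyond the scatter) and a 2.2-fold higher number from compound 2 to compound 4 (0.33 log units; beyond the scatter) and also a 2.6-fold higher number from compound 1 to compound 4 (0.41 log units; beyond the scatter) as modest weakening steps. No measurement shown here accounts for this.

Compound 4 changes both the group and its place on the ring, so the effect of the methoxy group cannot be separated from the effect of its place. As far as these compounds go, how an amine or a carboxylic acid on this phenyl ring would behave also remains open.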